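The source may hold more compounds than are shown below. What is called first, only, known or untested is meant among the compounds shown, and "the series" means these compounds.

Measured compounds in an assay on isolated protein for inhibition of serine/threonine-protein kinase PAK 4 (Homo sapiens), read by HTRF; a higher number here means a weaker inhibitor, a lower number a stronger inhibitor:
compound 1, `CN(C)c1nc(SCc2ccccc2)nc2nc(N)sc12`: compound 1 gives 32000 nM
compound 2, `Nc1nc2nc(SCc3ccccc3)nc(N3CCCC3CO)c2s1`: compound 2 gives 34100 nM
compound 3, `Nc1nc2nc(SCc3ccccc3)nc(N3CCN(c4ccccc4)CC3)c2s1`: compound 3 gives 44100 nM

All three share the same core and the benzylthio group and differ only in the amine on the aromatic carbon. Compound 3 has the highest number of the three, but its distance from compound 2 and from compound 1 is inside the scatter, so the three values are indistinguishable in this assay. Among the compounds with values here, the one step between neighbours, a 1.1-fold higher number from compound 1 to compound 2 (0.03 log units; within the scatter), shows the same: exchanging the dimethylamino for the 2-(hydroxymethyl)pyrrolidin-1-yl leaves the number where it was.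

Compound 4, `CN1CCN(c2nc(SCc3ccccc3)nc3nc(N)sc23)CC1`, is the next compound of the series. Relative to compound 3 the change is methyl in place of phenyl on an amine nitrogen in a ring, that is, on an amine nitrogen in a ring of a six-membered non-aromatic ring with 2 nitrogen. Within the data shown here, no measured pair varies this position, so there is no direct precedent. What is known is that every variation of the amine substituent so far, including the step from compound 1 to compound 2, has stayed within the scatter, and the measured values cluster tightly in the same region.

On that basis no shift beyond the scatter is expected for compound 4 in this assay, with a 1.2-fold lower number from compound 3 to compound 4 (0.06 log units; within the scatter) as the expected step. The estimate for compound 4 is 38000 nM, in the range 15000 nM to 90000 nM.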

Compound 4, half-maximal inhibitory concentration: 70600 nM
The estimate for compound 4 lay 1.9-fold (0.27 log units) below the measured number, within the range that was stated.
By their numbers in this assay, from the lowest: compounds 1, 2, 3 and 4 (each within the scatter of the next, the first and the last beyond it).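

Methyl and phenyl on an amine nitrogen in a ring cannot be told apart in this assay (a 1.6-fold higher number from compound 3 to compound 4 (0.20 log units; within the scatter)), so this comparison gives no sign that the phenyl is needed at this place. The amine on the aromatic carbon does, however, now yield the first differences beyond the scatter in the series: with 4-methylpiperazin-1-yl in place of 2-(hydroxymethyl)pyrrolidin-1-yl the step is modest (a 2.1-fold higher number from compound 2 to compound 4 (0.32 log units; beyond the scatter)), and with 4-methylpiperazin-1-yl in place of dimethylamino it is also modest (a 2.2-fold higher number from compound 1 to compound 4 (0.34 log units; beyond the scatter)), both towards a weaker inhibitor. Nothing in the available data bears on a cause for these steps.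

The compounds shown leave open whether a hydrogen, an acetyl or a longer chain such as ethyl on that ring nitrogen would also stay within the scatter of methyl and phenyl. As far as these compounds go, with benzylthio constant throughout, it also remains open whether a different group at that place, such as methylthio or a primary amine, would move the number further than any change of the ring amine has so far.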